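Acyl variation on the shared core: cyclopropyl to cyclobutyl

The source may hold more compounds than are shown below. What is called first, only, known or untested is meant among the compounds shown, and "the series" means these compounds.

Measured so far in an assay on Sf9 cells for inhibition of inhibitor of nuclear factor kappa-B kinase subunit epsilon (Homo sapiens), read by ADP-Glo, with a stated time of 60 min; on this read-out lower numbers stand for stronger inhibition and higher numbers for weaker inhibition:
Compound 1 `CCC(=O)n1nc(C)c(-c2ccc(Cl)c(Cl)c2)c1N` reaches only > 100000 nM, which is a limit of this assay and not a number.
Compound 2 `Cc1nn(C(=O)C2CC2)c(N)c1-c1ccc(Cl)c(Cl)c1` reaches only > 100000 nM, again a limit of this assay and not a number.

Compound 2 therefore stands at the limit of this assay; the limit of > 100000 nM in this assay, at which 2 of the 2 values shown sit, records that both values shown sit there. The step from compound 1 to compound 2 reads a step that the two limits leave unreadable from compound 1 to compound 2; two limits leave its size and direction unreadable.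

Compound 3 `Cc1nn(C(=O)C2CCC2)c(N)c1-c1ccc(Cl)c(Cl)c1` differs from compound 2 by cyclobutyl in place of cyclopropyl on a carbonyl carbon. Among the measured compounds shown here, the only measured step concerns the same carbonyl substituent, and since it is unreadable it gives no direction for a further enlargement of that ring. Compound 2 itself sits at the limit, so any outcome for compound 3 below the limit would have to appear without precedent in this assay.

For compound 3 the expected step of a number no higher from compound 2 to compound 3 (the limit leaves the size open) is set at essentially none, with a high chance that only a limit is reported again. Compound 3 is thus estimated at about 100000 nM, within a range of 30000 nM to 300000 nM.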

Compound 3, half-maximal inhibitory concentration: > 100000 nM
Compound 3: a limit, no number; the forecaster's own chance of this, stated with the estimate: 85%; the middle value lies on the limit itself.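

In this assay compound 3 gives > 100000 nM as a limit and not a number. Among the compounds shown here, no step among compound 1, compound 2 and compound 3 can be read, since all three sit at the same limit: the limit of > 100000 nM in this assay, at which 3 of the 3 values shown sit. The compounds shown leave open how ethyl, cyclopropyl and cyclobutyl on the carbonyl carbon rank in this assay and whether any such group on the shared core gives a measurable value.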